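Methoxy in Place of Trifluoromethyl: Expected Growth Inhibition

The source may report more compounds than this note shows. Statements on the series, on what has been measured and on what is new or still open speak of the compounds shown alone.

Measured compounds:
compound 1, `COc1cccc2sc(NC(=O)c3ccc(C(F)(F)F)cc3)nc12`, > 10 ug/mL
compound 2, `COc1ccc(C(=O)Nc2nc3cc(C)cc(C)c3s2)cc1`, 1.03 ug/mL

Compound 1 was tested in a functional assay on MDA-MB-231 cells (Homo sapiens) for antiproliferative activity, read by sulforhodamine B assay; a lower number here means a stronger inhibitor of growth, a higher number a weaker inhibitor of growth. For compound 1 only a limit is known, > 10 ug/mL, which is not a number but the edge of the assay. Compound 1 thus stands at the limit of > 10 ug/mL in this assay, at which 1 of the 2 values shown sits. For the measured compounds named here, compound 2 gives 1.03 ug/mL in this assay; it carries the same methoxy-bearing amide that compound 3 will carry, but on a core with two methyl groups rather than the core of compound 1, and no single-point step connects it to either compound 1 or compound 3.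

Compound 3, `COc1ccc(C(=O)Nc2nc3c(OC)cccc3s2)cc1`, is not yet measured. It differs from compound 1 by methoxy in place of trifluoromethyl on an aromatic carbon.

Going by the values given here, since the only known point for compound 1 is a limit, the size of the step cannot be read from data, and the estimate rests on the value of compound 2 showing that this amide can reach a measurable concentration. Compound 3 is expected to give 4 ug/mL, with a range from 1.2 ug/mL to 12 ug/mL. The expected step of an at least 2.5-fold lower number from compound 1 to compound 3 (0.39 log units; beyond the scatter) is toward stronger inhibition, likely beyond the scatter, though a second limit remains possible.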

Compound 3, concentration for 50% growth inhibition: 1.25 ug/mL
The estimate for compound 3 lay 3.2-fold (0.51 log units) above the measured number; low and high end bracket the measured number.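

With the core of compound 1 held fixed, methoxy in place of trifluoromethyl on this aromatic carbon, para to a large group, gives an at least 8.0-fold lower number from compound 1 to compound 3 (0.90 log units; beyond the scatter) in this assay. This shows that a change at this one place is enough to bring growth inhibition on this core to a measurable concentration, with compound 3 at 1.25 ug/mL in this assay. For compound 1 the value > 10 ug/mL is a limit of the assay and not a number, and the step is only a minimum because it starts from such a limit: the limit of > 10 ug/mL in this assay, at which 1 of the 3 values shown sits.

The compounds shown leave open how far compound 1 really lies from compound 3, and whether the gain belongs to methoxy in particular or would also appear with another group at this place, such as a hydroxyl, an amine or a longer chain like ethoxy. They also leave open whether the same change would act in the same way on a different core, since this single pair sets no general pattern.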